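The compounds below may be only part of what the source reports. "The series", "measured", "known", "first", "only" and "open" are said of these compounds alone.

Three close relatives of one shared core have been measured. Compound 1 `Cc1ccc2oc(CSc3nc4nc(C)cc(C)n4n3)cc(=O)c2c1` bears a methyl on an aromatic carbon. In a functional assay on LM7 cells (Homo sapiens) for cytotoxicity, read by MTT assay, with a stated time of 72 h (a higher number here means a weaker inhibitor, a lower number a stronger inhibitor), compound 1 gives > 25000 nM, which is a limit of the assay and not a number. Compound 2 `Cc1cc(C)n2nc(SCc3cc(=O)c4cc(Cl)ccc4o3)nc2n1` carries a chloro in place of that methyl. In this assay compound 2 gives > 25000 nM, again a limit. Compound 3 `Cc1cc(C)nc(SCc2cc(=O)c3ccccc3o2)n1` differs in the part joined through the sulfur and has no substituent on the corresponding aromatic carbon. In this assay compound 3 gives > 25000 nM, also a limit. Among the measured compounds shown here, the only step between compounds that differ in one place, a step that the two limits leave unreadable from compound 1 to compound 2, cannot be read, and all three values sit at the limit of > 25000 nM in this assay, at which 3 of the 3 values shown sit.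

Compound 2 therefore stands at the edge of what this assay can report, with no number to rank it against the others. Compound 4 `Cc1cc(C)n2nc(SCc3cc(=O)c4ccccc4o3)nc2n1` differs from compound 2 by hydrogen in place of chloro on an aromatic carbon. For the measured compounds named here, no measured step reports this particular change, and the one step that touches the same position is unreadable. Since every measured value, including that of compound 3 with an unsubstituted aromatic carbon, sits at the limit, compound 4 is expected to behave alike, with an estimated step that the limit leaves unreadable from compound 2 to compound 4. Compound 4 is thus estimated at 35000 nM, with a range from 12000 nM to 100000 nM.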

Compound 4, half-maximal inhibitory concentration: > 25000 nM
Compound 4: a limit, no number; the forecaster's own chance of this, stated with the estimate: 85%; the middle value lies beyond the limit too.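

In this assay compound 4 gives > 25000 nM, a limit and not a number. The steps from compound 1 and compound 2 to compound 4 cannot be read, because every value sits at the same limit: the limit of > 25000 nM in this assay, at which 4 of the 4 values shown sit.

Left open is how strongly any of these compounds acts on the cells, and whether methyl, chloro or hydrogen on that aromatic carbon makes any difference.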